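Removing the 4-Fluorophenyl from the Ring Nitrogen

This account rests on a few compounds, and the source may have more. Where it says the series, first, only, none or still open, it means among the compounds named here.

Measured compounds and their values in a functional assay on A-375 cells (Homo sapiens) for antiproliferative activity, read by MTT assay, with a stated time of 72 h; on this read-out higher numbers stand for weaker inhibition and lower numbers for stronger inhibition:
Compound 1 `O=C1COc2ccc(-c3cnc(Cl)c(NS(=O)(=O)c4ccc(F)cc4)c3)cc2N1C1CCCCC1`: > 40000 nM
Compound 2 `CC(C)N1C(=O)COc2ccc(-c3cccc(NS(=O)(=O)c4ccc(F)cc4)c3)cc21`: > 40000 nM
Compound 3 `O=C1COc2ccc(-c3cccc(NS(=O)(=O)c4ccc(F)cc4)c3)cc2N1c1ccc(F)cc1`: > 40000 nM

For compound 3 the value in this assay is a limit of the assay, not a measured number. The same holds for compound 1, whose value is a limit. Compound 2 likewise shows only a limit. This is the limit of > 40000 nM in this assay, at which 3 of the 3 values shown sit, so all three compounds stand at the same edge of what the assay can report. Of the one-place step that the two limits leave unreadable from compound 2 to compound 3 nothing can be read, as both of its ends are limits.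

Compound 4 `O=C1COc2ccc(-c3cccc(NS(=O)(=O)c4ccc(F)cc4)c3)cc2N1` is the next compound to be measured. It differs from compound 3 in one place: hydrogen in place of 4-fluorophenyl on an amide-type nitrogen in a ring. Going by the values given here, no measured step gives a readable size for any change at this nitrogen, so there is no basis for expecting a move away from the limit. The step from compound 3 to compound 4 is therefore expected to be a number no higher from compound 3 to compound 4 (the limit leaves the size open), that is, nothing beyond the usual scatter. Compound 4 is expected to give about 40000 nM, within a range from 10000 nM to 120000 nM, most likely again reported only as a limit.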

Compound 4, half-maximal inhibitory concentration: 20100 nM
Beside the measured number, compound 4's estimate is 2.0-fold (0.30 log units) above it, within the range that was stated.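

Compound 4, with hydrogen on the amide-type nitrogen in the ring, is the first compound here to give a measured number instead of a limit of the assay in this assay, while the others stay at the assay's edge: the limit of > 40000 nM in this assay, at which 3 of the 4 values shown sit.

Replacing 4-fluorophenyl with hydrogen gives an at least 1.9-fold lower number from compound 3 to compound 4 (0.29 log units; that floor lies within the scatter), and replacing isopropyl with hydrogen gives an at least 1.9-fold lower number from compound 2 to compound 4 (0.29 log units; that floor lies within the scatter). Each of these sizes is a floor set by a limit: the true change may be larger, but the floor itself lies within the usual scatter.

The compounds shown leave open what a methyl group, or a short chain ending in an amine or a carboxylic acid, would do on this nitrogen. They also leave open how changes elsewhere on the shared core would act while this nitrogen carries hydrogen.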